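The source may hold more compounds than are shown below. What is called first, only, known or untested is meant among the compounds shown, and "the series" means these compounds.

Compound 1 `CCC1=C(c2cc(OC)c(OC)c(OC)c2)c2ccc(OC)c(O)c2CCC1` gives 136 mL.min-1.g-1 in an ADME assay (liver) for metabolic stability, with Liver microsome (Homo sapiens) as the target, using microsomes, tested at 1 uM; a higher number here means faster removal of the compound, a lower number slower removal. Compound 2 `COc1ccc2c(c1O)CCCC(CCC#N)=C2c1cc(OC)c(OC)c(OC)c1` reaches only a limit of that assay, > 320 mL.min-1.g-1, in this assay. Among the measured compounds shown here, the one measured step, an at least 2.3-fold higher number from compound 1 to compound 2 (0.37 log units; beyond the scatter), runs toward (the limit of > 320 mL.min-1.g-1 in this assay, at which 1 of the 2 values shown sits). Compound 3 `COc1ccc2c(c1O)CCCC(C)=C2c1cc(OC)c(OC)c(OC)c1` differs from compound 2 by hydrogen in place of cyanomethyl on a saturated chain carbon bound to a double-bonded ring carbon. That measured step bears directly on this change, as it removes the cyano group that the step introduced, so the step is expected to run the other way, with an estimated at least 2.4-fold lower number from compound 2 to compound 3 (0.39 log units; beyond the scatter) in this assay. Compound 3 is therefore expected to give 130 mL.min-1.g-1, within 65 mL.min-1.g-1 to 260 mL.min-1.g-1, in this assay.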

Compound 3, intrinsic clearance in microsomes: 108 mL.min-1.g-1
Estimate against measurement, compound 3: 1.2-fold (0.08 log units) above; measured number inside the range.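

In this assay, hydrogen in place of cyanomethyl gives an at least 2.9-fold lower number from compound 2 to compound 3 (0.47 log units; beyond the scatter), whereas hydrogen in place of methyl gives a 1.3-fold lower number from compound 1 to compound 3 (0.10 log units; within the scatter). Among these compounds, then, only the chain carrying the nitrile stands apart, while compound 1 and compound 3 do not separate. The first step remains a bound and not an exact size, since the value of compound 2 is a limit: the limit of > 320 mL.min-1.g-1 in this assay, at which 1 of the 3 values shown sits. On these data alone, whether a longer chain without the nitrile, an amine or a carboxylic acid at this position would behave like compound 2 or like compound 3 stays open.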